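Notes on the step from compound 2 to compound 3

The compounds below may be only part of what the source reports. "The series", "measured", "known", "first", "only" and "open" are said of these compounds alone.

- compound 1 `C=C1C(=O)O[C@H]2[C@H]1CC/C(COC(=O)Cn1cc(F)c(=O)n(Cc3ccc([N+](=O)[O-])cc3)c1=O)=C\CC[C@@]1(C)O[C@@H]21` gives 4340 nM
- compound 2 `C=C1C(=O)O[C@H]2[C@H]1CC/C(COC(=O)Cn1cc(F)c(=O)n(C)c1=O)=C\CC[C@@]1(C)O[C@@H]21` gives 11700 nM

In a functional assay on Bel7402/5-FU cells (Homo sapiens) for antiproliferative activity, read by MTT assay, with a stated time of 72 h (a higher number here means a weaker inhibitor, a lower number a stronger inhibitor), compound 2 at 11700 nM holds the higher of the two numbers. Compound 3 `C=C1C(=O)O[C@H]2[C@H]1CC/C(COC(=O)Cn1cc(F)c(=O)n(CCC)c1=O)=C\CC[C@@]1(C)O[C@@H]21` differs from it by ethyl in place of hydrogen on a saturated chain carbon bound to an aromatic nitrogen in a change of methyl to propyl. Going by the values given here, one measured step bears on this: a 2.7-fold higher number from compound 1 to compound 2 (0.43 log units; beyond the scatter) with hydrogen in place of 4-nitrophenyl. That single step sets no pattern, so only a small move to a lower number is expected, possibly within the scatter. The expected step is a 1.4-fold lower number from compound 2 to compound 3 (0.14 log units; within the scatter) by estimate. For compound 3 the estimated value is 8500 nM with an expected range from 4000 nM to 16000 nM in this assay here.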

Compound 3, half-maximal inhibitory concentration: 9110 nM
Estimate against measurement, compound 3: 1.1-fold (0.03 log units) below; measured number inside the range.
By their numbers in this assay, from the lowest: compound 1; then compounds 3 and 2 (each within the scatter of the next).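

In this assay, the change of methyl to propyl on a saturated chain carbon bound to an aromatic nitrogen gives a 1.3-fold lower number from compound 2 to compound 3 (0.11 log units; within the scatter), so this added ethyl leaves the number unmoved within the scatter. The 4-nitrophenyl group still stands apart from the propyl end of the series, with a 2.1-fold higher number from compound 1 to compound 3 (0.32 log units; beyond the scatter), a modest step. No measured evidence on this series accounts for either step.

As far as these compounds go, whether a plain phenyl without the nitro group, or a longer chain such as hexyl, would reach the number of compound 1 remains open.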